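The source may report more compounds than this note shows. Statements on the series, on what has been measured and on what is new or still open speak of the compounds shown alone.

Compound 2 `O=C(O)[C@@H](CO)NC(=O)[C@H]1C[C@H](O)CN1` is one of three stereoisomers of the same molecule. In an ADME assay (Mus musculus, strain C57BL/6) for metabolic stability, read by HPLC, with a stated time of 12 h (a lower number here means that the compound disappears faster, a higher number that the compound lasts longer), compound 2 gives > 12 h, which is a limit of the assay rather than a number. Compound 1 `O=C(O)[C@@H](CO)NC(=O)[C@H]1C[C@@H](O)CN1` also gives a limit in this assay, > 12 h. Compound 3 `O=C(N[C@H](CO)C(=O)O)[C@@H]1C[C@@H](O)CN1` gives a number, 0.91 h. Because of the limit of > 12 h in this assay, at which 2 of the 3 values shown sit, the step from compound 1 to compound 2 is a step that the two limits leave unreadable from compound 1 to compound 2. The configuration changes that do show a size are large: an at least 13-fold lower number from compound 1 to compound 3 (1.12 log units; beyond the scatter) and an at least 13-fold lower number from compound 2 to compound 3 (1.12 log units; beyond the scatter), each a change of configuration alone, as shown by the fact that compounds 1 and 3 differ only in the configuration as drawn and (the fact that compounds 2 and 3 differ only in the configuration as drawn).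

Compound 4 `O=C(O)[C@H](CO)NC(=O)[C@@H]1C[C@@H](O)CN1` is the next step from compound 2, and the change is the two compounds have the same atoms and bonds and differ only in configuration as drawn: 3 of 3 stereo elements differ (all stereocentres are inverted: mirror images); a stereocentre at a saturated chain carbon is drawn R in compound 2 and S in compound 4; a stereocentre at a saturated ring carbon is drawn R in compound 2 and S in compound 4; a stereocentre at a saturated ring carbon is drawn S in compound 2 and R in compound 4. Among the measured compounds shown here, no measured step inverts all three centres. The measured steps bear on compound 4 only indirectly. The step from compound 2 to compound 4 is therefore expected to be an at least 4.0-fold lower number from compound 2 to compound 4 (0.60 log units; beyond the scatter), with wide uncertainty. For compound 4 the half-life in this assay is estimated at 3 h, between 0.5 h and 12 h.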

Compound 4, half-life: 0.86 h
Estimate against measurement, compound 4: 3.5-fold (0.54 log units) above, and the stated range covers the measured number.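

In this assay, inverting the chain stereocentre alone gives a 1.1-fold lower number from compound 3 to compound 4 (0.02 log units; within the scatter), so this centre on its own has no readable effect in this pair: the fact that compounds 3 and 4 differ only in the configuration as drawn. Full inversion of compound 2 nevertheless gives an at least 13-fold lower number from compound 2 to compound 4 (1.14 log units; beyond the scatter), and the two-centre change gives an at least 13-fold lower number from compound 1 to compound 4 (1.14 log units; beyond the scatter), both changes of configuration alone: the fact that compounds 1 and 4 differ only in the configuration as drawn. Compounds 3 and 4 share their ring configuration, and among these four compounds the short half-life stays with that ring configuration whichever way the chain carbon is drawn.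

From the compounds shown here alone, what remains open is whether the chain centre matters when the ring configuration is that of compound 1 or compound 2, whose half-lives are limits and not numbers. Going by these compounds, it is also open whether an ester in place of the carboxylic acid would show the same dependence on configuration.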